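This account rests on a few compounds, and the source may have more. Where it says the series, first, only, none or still open, it means among the compounds named here.

Compound 1 `COc1nc2ccccc2n1C(=O)NCCCCc1ccccc1` is the starting point, and it is known only through a limit. In a physicochemical assay for metabolic stability, read by HPLC, at pH 4.5, tested at 10 uM (on this read-out higher numbers stand for a longer-lived compound and lower numbers for a shorter-lived compound), compound 1 gives > 2 h, which is a limit of the assay and not a number. Compound 2 `O=C(NCCCCc1ccccc1)N1C(=O)c2ccccc2C1=O` gives > 2 h, which is likewise a limit. Compound 3 `O=C(NCCCCc1ccccc1)n1c(=O)n(C(=O)NCCCCc2ccccc2)c2ccccc21` gives > 2 h, which is a limit too. Compound 1 therefore has no exact place among the three, and no order can be drawn between them.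

Compound 4 `O=C(NCCCCc1ccccc1)n1cnc2ccccc21` departs from compound 1 in one place: hydrogen in place of methoxy on an aromatic carbon. Hydrogen stands in place of methoxy on an aromatic carbon, between two ring nitrogen atoms and next to the ring atom that bears a large group. Within the data shown here, no measured pair shows what this exchange does in this assay, so its size has to be judged from the set as a whole. The expectation rests on (the limit of > 2 h in this assay, at which 3 of the 3 values shown sit). On that basis, no step beyond the usual scatter is expected, although any shift that did appear is expected to lean towards a shorter life. As an estimate, this is a number no higher from compound 1 to compound 4 (the limit leaves the size open). For compound 4 the estimated half-life is 2 h, with an expected range of 0.7 h to 6 h.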

Compound 4, half-life: > 2 h
Compound 4 gave a limit, no number; the forecaster's own chance of this, stated with the estimate: 60%; the middle value sits exactly at the limit.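

Compound 4 gives > 2 h, which is a limit of the assay and not a number. Compound 1 is also known only through a limit, so no step can be read between compound 1 and compound 4. The true half-lives of all four compounds in this assay, and their order, stay open: the limit of > 2 h in this assay, at which 4 of the 4 values shown sit.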